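Shifting the halogen on the benzoyl ring of compound 2

The compounds below may be only part of what the source reports. "The series", "measured", "known", "first", "only" and "open" are said of these compounds alone.

Of the compounds shown here, three of one shared core have been measured in a functional assay on DU-145 cells (Homo sapiens) for inhibition, read by trypan blue exclusion, with a stated time of 96 h; a higher number here means a weaker inhibitor of growth, a lower number a stronger inhibitor of growth. Compound 1 `Cc1ccsc1/C=C(/SCc1ccc(Cl)cc1)C(=O)c1ccc(Br)cc1` gives 25000 nM, compound 2 `O=C(/C(=C\c1ccc(Cl)cc1)SCc1ccc(Cl)cc1)c1ccc(Br)cc1` gives 10000 nM, and compound 3 `COc1ccc(/C=C(/SCc2ccc(Cl)cc2)C(=O)c2ccc(Br)cc2)cc1O` gives 1000 nM. Compound 2 thus stands second highest of the three numbers: its nearest neighbour is compound 1, with a 2.5-fold lower number from compound 1 to compound 2 (0.40 log units; beyond the scatter), and its furthest is compound 3, with a 10-fold lower number from compound 2 to compound 3 (1.00 log units; beyond the scatter). Both of those steps, as well as a 25-fold lower number from compound 1 to compound 3 (1.40 log units; beyond the scatter), concern the aryl group on the double-bonded chain carbon; none of them touches the carbonyl side of the molecule.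

Compound 4 `O=C(/C(=C\c1ccc(Cl)cc1)SCc1ccc(Cl)cc1)c1ccccc1Cl` differs from compound 2 exactly there: 2-chlorophenyl in place of 4-bromophenyl on a carbonyl carbon. Among the compounds with values here, no measured step in this assay bears on such a change, so there is nothing in the data to point either way, and the expectation for compound 4 in this assay is a step that stays within the scatter, no change at the digits printed from compound 2 to compound 4 (within the scatter). Compound 4 is therefore estimated at 10000 nM, with a range from 3000 nM to 30000 nM kept deliberately wide.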

Compound 4, concentration for 50% growth inhibition: 30000 nM
The estimate for compound 4 lay 3.0-fold (0.48 log units) below the measured number; measured number inside the range.
By their numbers in this assay, from the lowest: compound 3; then compound 2; then compounds 1 and 4 (each within the scatter of the next).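

In this assay, within the data shown here, the carbonyl side of the molecule proves able to move the number, which the earlier compounds could not show, as all their steps lay on the aryl group of the double-bonded chain carbon: 2-chlorophenyl in place of 4-bromophenyl on the carbonyl carbon gives a 3.0-fold higher number from compound 2 to compound 4 (0.48 log units; beyond the scatter). The direction is toward weaker growth inhibition, so, of these two groups on this carbonyl carbon, 4-bromophenyl is the one that goes with the lower number when the rest of compound 2 is held fixed. No measured evidence explains this step, and the data give no reason for it.

The halogen and its place on the ring change together in this one step, so the compounds shown leave open which of the two carries the effect; 4-chlorophenyl or 2-bromophenyl on the carbonyl carbon would separate them, and plain phenyl or a phenyl bearing an amine would show whether a halogen is needed there at all. Going by these compounds, it also remains open whether the same change would hold on the core of compound 3, which carries 3-hydroxy-4-methoxyphenyl on the double-bonded chain carbon.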